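Exocyclic aryl exchange: from compound 2 toward compound 3

This account rests on a few compounds, and the source may have more. Where it says the series, first, only, none or still open, it means among the compounds named here.

Compound 1 `O=C1N=C(N2CCC[C@H]2C(=O)Nc2ccc3ncnc(Nc4cccc(Cl)c4)c3c2)S/C1=C/c1cccc(Cl)c1` — 27600 nM
Compound 2 `O=C1N=C(N2CCC[C@H]2C(=O)Nc2ccc3ncnc(Nc4cccc(Cl)c4)c3c2)S/C1=C/c1cccc(Br)n1` — 2700 nM

Among the measured compounds shown here, in a functional assay on HepG2 cells (Homo sapiens) for antiproliferative activity, read by MTT assay (a lower number here means a stronger inhibitor, a higher number a weaker inhibitor), compound 2 gives 2700 nM, the lowest of the two numbers measured so far; the only other measured compound stands apart by a 10-fold lower number from compound 1 to compound 2 (1.01 log units; beyond the scatter). Compound 3 `O=C1N=C(N2CCC[C@H]2C(=O)Nc2ccc3ncnc(Nc4cccc(Cl)c4)c3c2)S/C1=C/c1ccccc1[N+](=O)[O-]` differs from compound 2 by 2-nitrophenyl in place of 6-bromopyridin-2-yl on a double-bonded chain carbon bound to a double-bonded ring carbon.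

For the measured compounds named here, the single measured step at this position is a 10-fold lower number from compound 1 to compound 2 (1.01 log units; beyond the scatter), which shows that the aryl group on the exocyclic carbon can move the number strongly. Going by the values given here, no measured step joins 6-bromopyridin-2-yl to 2-nitrophenyl, so the direction for compound 3 rests on one step only. Since the carbon-only ring of compound 1 gave the higher number, compound 3 is expected to give a higher number than compound 2, by about a 2.6-fold higher number from compound 2 to compound 3 (0.41 log units; beyond the scatter), with wide uncertainty. For compound 3 in this assay the estimate is 7000 nM, with a range of 1500 nM to 30000 nM.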

Compound 3, half-maximal inhibitory concentration: 32500 nM
Compound 3: the middle estimate sits 4.6-fold (0.67 log units) below what was measured, outside the stated range (above it).
By their numbers in this assay, from the lowest: compound 2; then compounds 1 and 3 (each within the scatter of the next).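

In this assay, the exchange gives a 12-fold higher number from compound 2 to compound 3 (1.08 log units; beyond the scatter), so the lower number of compound 2 does not carry over to 2-nitrophenyl, even though this group has more heavy atoms and one more hydrogen-bond acceptor than 6-bromopyridin-2-yl. The exchange between the two carbon-only rings gives a 1.2-fold higher number from compound 1 to compound 3 (0.07 log units; within the scatter), which leaves 2-nitrophenyl and 3-chlorophenyl unseparated, and 6-bromopyridin-2-yl alone stands apart among the three groups at this position. No evidence bearing on this gap is available.

From the compounds shown here alone, with a single pyridine ring in the set, it remains open whether the lower number goes with the ring nitrogen or with the bromine, a question that an unsubstituted pyridine ring and a bromophenyl ring would separate. Also open, going by these compounds, is how an amine or a carboxylic acid on the aryl ring would behave at this position.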